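A few compounds are considered here, and "the series" means these few. Any claim that something is new, unique, unknown or untested is made for them only; others in the source may bear on it.

Compound 1 `CN(C)C1CCN(c2nccnc2OC2CN(c3ccc4ccccc4n3)C2)CC1`: 500000 nM
Compound 2 `NC(=O)C1CCN(c2nccnc2OC2CN(c3ccc4ccccc4n3)C2)CC1`: 14000 nM

Both values come from a physicochemical assay for solubility, in phosphate buffer, at pH 7.4; a higher number here means a more soluble compound, a lower number a less soluble compound. Compound 2 holds the lower of the two numbers, and the gap to compound 1 lies beyond the scatter. The next compound is compound 3 `c1ccc2nc(N3CC(Oc4nccnc4-c4ccncc4)C3)ccc2c1`. The change is pyridin-4-yl in place of 4-carbamoylpiperidin-1-yl on an aromatic carbon. Among the compounds with values here, the only measured step that bears on this is a 36-fold lower number from compound 1 to compound 2 (1.55 log units; beyond the scatter). That large step came from a swap on the six-membered non-aromatic ring that compound 3 no longer has, so it hints at how far the number can move here. Within the data shown here, no measured compound carries pyridin-4-yl, so the direction remains a judgement, and a moderate drop in this assay seems likeliest. The expected change is a 4.7-fold lower number from compound 2 to compound 3 (0.67 log units; beyond the scatter), with wide uncertainty. For compound 3 the estimated value is 3000 nM, with an expected range from 600 nM to 15000 nM.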

Compound 3, solubility: 56000 nM
Compound 3: middle estimate off by 19-fold (1.27 log units), on the low side; measured number above the stated range.
By their numbers in this assay, from the lowest: compound 2; then compound 3; then compound 1.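

In this assay, pyridin-4-yl on this aromatic carbon gives a 4.0-fold higher number from compound 2 to compound 3 (0.60 log units; beyond the scatter), so a number at this position need not fall when 4-carbamoylpiperidin-1-yl gives way to an aromatic ring with fewer heavy atoms. Set against the dimethylamino partner, the same kind of swap gives an 8.9-fold lower number from compound 1 to compound 3 (0.95 log units; beyond the scatter). Compound 3 therefore sits between the two compounds that carry a six-membered non-aromatic ring here, which shows that whether this ring is aromatic does not alone set the order of the three numbers.

As far as these compounds go, it remains open how a carboxylic acid on the six-membered non-aromatic ring, or pyridin-3-yl on the same aromatic carbon, would compare with these three compounds. No measurement available here explains why the number moves as it does.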